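The compounds below may be only part of what the source reports. "The series", "measured", "known", "first", "only" and "open" are said of these compounds alone.

Compound 1 `CCOC(=O)/C(CCCC(=O)O)=N\Nc1ccc(Cl)cc1`: 20000 nM
Compound 2 `CCOC(=O)/C(CCCC(=O)O)=N\Nc1ccc(Br)cc1`: 21000 nM

In an assay on isolated protein for inhibition of kynurenine--oxoglutarate transaminase 1 (Homo sapiens), read by HPLC, with a stated time of 20 min (on this read-out lower numbers stand for stronger inhibition and higher numbers for weaker inhibition), compound 2 gives 21000 nM, the highest of the two numbers, with compound 1 nearest at 20000 nM, a gap that lies within the scatter. Compound 3 `CCOC(=O)/C(CCCC(=O)O)=N\Nc1ccc([N+](=O)[O-])cc1` differs from compound 2 by nitro in place of bromo on an aromatic carbon. Within the data shown here, the only measured step that bears on a change at this position is a 1.1-fold higher number from compound 1 to compound 2 (0.02 log units; within the scatter), which stayed within the scatter. Compound 3 is therefore expected to show no step beyond the scatter in this assay, an expected 1.1-fold lower number from compound 2 to compound 3 (0.02 log units; within the scatter). For compound 3 the estimated value is 20000 nM, expected to fall between 8000 nM and 50000 nM.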

Compound 3, half-maximal inhibitory concentration: 179000 nM
For compound 3 the middle estimate is 9.0-fold (0.95 log units) below the measured one; measured number above the stated range.
By their numbers in this assay, from the lowest: compounds 1 and 2 (each within the scatter of the next); then compound 3.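

The aromatic carbon where bromo and chloro gave matching numbers does not accept every group: in this assay, nitro brings an 8.5-fold higher number from compound 2 to compound 3 (0.93 log units; beyond the scatter), and against chloro it brings a 9.0-fold higher number from compound 1 to compound 3 (0.95 log units; beyond the scatter). The position therefore responds to the group placed on it, and compound 3 is the weakest inhibitor of the three. Nothing available gives a reason for this loss. The compounds shown leave open how an amine, a methoxy group or a nitrile would fare on this same carbon. They also leave open whether a shorter or longer acid chain would change the picture.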